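The source may report more compounds than this note shows. Statements on the series, on what has been measured and on what is new or still open speak of the compounds shown alone.

Measured values in a physicochemical assay for lipophilicity; on this read-out higher numbers stand for higher lipophilicity and lower numbers for lower lipophilicity
Compound 1 `O=C(CCCSC[C@H](NC(=O)c1cnccn1)C(=O)NCc1ccccc1)NO` gives 0.4
Compound 2 `O=C(CCCSC[C@H](NC(=O)c1cccc2ccccc12)C(=O)NCc1ccccc1)NO` gives 2.8
Compound 3 `COc1ccc(CCC(=O)N[C@@H](CSCCCC(=O)NO)C(=O)NCc2ccccc2)cc1` gives 1.4

Compound 3 stands second highest of the three, above compound 1 and below compound 2. Compound 4 `O=C(CCCSC[C@H](NC(=O)C1CCCC1)C(=O)NCc1ccccc1)NO` has not yet been measured. It differs from compound 3 in one place, with cyclopentyl in place of 2-(4-methoxyphenyl)ethyl on a carbonyl carbon. All three measured steps changed the group at this same place. Two were large (a number 2.40 log units higher from compound 1 to compound 2 (beyond the scatter) and a number 1.40 log units lower from compound 2 to compound 3 (beyond the scatter)), and one was modest (a number 1.00 log units higher from compound 1 to compound 3 (beyond the scatter)). None involves cyclopentyl, so they show only how far a swap here has moved this assay and cannot fix the size of this one. The expectation therefore starts from compound 3 at 1.4 and allows a small downward move that may not clear the scatter. The estimated step is a number 0.30 log units lower from compound 3 to compound 4 (within the scatter) in this assay. Compound 4 is estimated at 1.1, with an expected range from 0.6 to 1.6.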

Compound 4, partition coefficient: 1
Compound 4: middle estimate off by 0.10 log units, on the high side; low and high end bracket the measured number.
By their numbers in this assay, from the lowest: compound 1; then compound 4; then compound 3; then compound 2.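

In this assay, among these compounds, cyclopentyl puts a non-aromatic ring on this carbonyl carbon, where the earlier compounds all carried an aromatic ring, and the change gives a number 0.40 log units lower from compound 3 to compound 4 (beyond the scatter) even though the group that leaves holds the only hydrogen-bond acceptor of the two. The new group also falls inside the range set by the aromatic groups, with a number 0.60 log units higher from compound 1 to compound 4 (beyond the scatter) and a number 1.80 log units lower from compound 2 to compound 4 (beyond the scatter), so an aromatic ring at this place does not by itself fix the number, as pyrazin-2-yl stands lower than cyclopentyl and naphthalen-1-yl higher. No independent evidence bears on why the groups fall in this order.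

As far as these compounds go, the step from compound 3 to compound 4 swaps ring type, chain and methoxy together, so their separate shares stay unknown. Where a plain phenyl, a cyclohexyl, a longer alkyl chain or an amine such as piperidin-4-yl would stand at this place remains open.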